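Trimming the amide chain of compound 1

The source may hold more compounds than are shown below. What is called first, only, known or untested is meant among the compounds shown, and "the series" means these compounds.

Measured in a functional assay on A549 cells (Homo sapiens) for antiproliferative activity, read by CCK-8 assay, with a stated time of 72 h; a lower number here means a stronger inhibitor of growth, a higher number a weaker inhibitor of growth:
- compound 1 (`CCC1C(=O)N(C)c2cnc(-n3ccc4cc(C(=O)NC(C)C)ccc43)nc2N1c1ccn(C)n1`) gives 22000 nM
- compound 2 (`CCCNC(=O)c1ccc2c(ccn2-c2ncc3c(n2)N(C2CCCC2)[C@H](CC)C(=O)N3C)c1`) gives 1640 nM

Compound 1 holds the higher of the two numbers, and the gap to compound 2 lies beyond the scatter. Among the measured compounds shown here, these two compounds differ in more than one place, so the series offers no measured single-place step. Compound 3 (`CCNC(=O)c1ccc2c(ccn2-c2ncc3c(n2)N(c2ccn(C)n2)C(CC)C(=O)N3C)c1`) changes compound 1 from isopropylcarbamoyl to ethylcarbamoyl (hydrogen in place of methyl on a saturated chain carbon bound to an amide-type nitrogen and a saturated chain carbon). In this assay, a step no larger than the scatter is expected, with no firm direction. For compound 3 the estimated value is 15000 nM (expected range 5000 nM to 40000 nM). This estimate means an expected step (a 1.5-fold lower number from compound 1 to compound 3 (0.17 log units; within the scatter)).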

Compound 3, concentration for 50% growth inhibition: 21700 nM
Estimate against measurement, compound 3: 1.4-fold (0.16 log units) below, and the stated range covers the measured number.
By their numbers in this assay, from the lowest: compound 2; then compounds 3 and 1 (each within the scatter of the next).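

Hydrogen in place of methyl on the saturated chain carbon, the change from isopropylcarbamoyl to ethylcarbamoyl, gives a 1.0-fold lower number from compound 1 to compound 3 (0.01 log units; within the scatter) in this assay. Among the compounds shown here, this is the only single-place step so far, and on the core of compound 1 the read-out does not separate the two chains. No available evidence bears on this flat step. Open, going by these compounds, is whether a longer chain, an amine or a carboxylic acid in place of the ethyl would give a step beyond the scatter at this position.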